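From methyl to non-1-en-1-yl on compound 2

The source may hold more compounds than are shown below. What is called first, only, known or untested is meant among the compounds shown, and "the series" means these compounds.

In a functional assay on HepG2 cells (Homo sapiens) for cytotoxicity, read by WST assay, with a stated time of 24 h (on this read-out higher numbers stand for lower toxicity in this test and lower numbers for higher toxicity in this test), compound 2 `Cc1cc(-c2ccc3cc(CO)ccc3c2)ccc1O` gives > 32 ug/mL, which is a limit of the assay and not a number. Compound 4 `CCCCCCCC=Cc1cc(-c2ccc3cc(CO)ccc3c2)ccc1O` differs from it by non-1-en-1-yl in place of methyl on an aromatic carbon, with the new chain on an aromatic carbon ortho to a hydroxy group. Compound 3 `CCCC=Cc1cc(-c2ccc3cc(CO)ccc3c2)ccc1O` gives 3.89 ug/mL, and compound 1 `CCCC=Cc1cc(-c2ccc3cc(C(=O)O)ccc3c2)ccc1O` gives 5.38 ug/mL. Pent-1-en-1-yl in place of methyl gave an at least 8.2-fold lower number from compound 2 to compound 3 (0.91 log units; beyond the scatter), the measured step closest to this change, so a drop of similar size is expected for compound 4. Hydroxymethyl in place of carboxy gave a 1.4-fold lower number from compound 1 to compound 3 (0.14 log units; within the scatter). The expected step is an at least 8.0-fold lower number from compound 2 to compound 4 (0.90 log units; beyond the scatter). Compound 4 is estimated at 4 ug/mL, with an expected range from 1.5 ug/mL to 12 ug/mL.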

Compound 4, concentration lethal to 50% of the cells: 5.51 ug/mL
Compound 4: the middle estimate sits 1.4-fold (0.14 log units) below what was measured, and the stated range covers the measured number.
By their numbers in this assay, from the lowest: compounds 3, 1 and 4 (each within the scatter of the next). At a limit, above all of these: compound 2.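

In this assay non-1-en-1-yl in place of methyl, on the aromatic carbon ortho to a hydroxy group, gives an at least 5.8-fold lower number from compound 2 to compound 4 (0.76 log units; beyond the scatter) and so the lower number holds for a second chain, not for pent-1-en-1-yl alone. Butyl in place of hydrogen on the chain gives a 1.4-fold higher number from compound 3 to compound 4 (0.15 log units; within the scatter) and so leaves the two chains not told apart in this assay. Compound 2 stands at a limit of the assay, not a number: the limit of > 32 ug/mL in this assay, at which 1 of the 4 values shown sits.

On these data alone, whether an ethyl group, a saturated nonyl chain or a chain ending in an amine would read the same at this position stays open.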